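The source may hold more compounds than are shown below. What is called first, only, known or untested is meant among the compounds shown, and "the series" means these compounds.

Measured so far:
compound 1 `CSc1nc2c([nH]1)C(=O)C(Br)=C(Br)C2=O` — in a functional assay on MCF7 cells (Homo sapiens) for antiproliferative activity (a higher number here means a weaker inhibitor, a lower number a stronger inhibitor), compound 1 gives 40.3 uM.
compound 2 `CN(C)C1=CC(=O)c2[nH]c(-c3ccccn3)nc2C1=O` — in this assay compound 2 gives only a limit, > 90 uM.

Compound 2 thus stands at the limit of > 90 uM in this assay, at which 1 of the 2 values shown sits, with no number of its own. Compound 3 `NC1=CC(=O)c2[nH]c(-c3ccccn3)nc2C1=O` differs from it by amino in place of dimethylamino on a double-bonded ring carbon. Among the compounds with values here, no measured pair covers this change, so the series gives no size or direction for it in this assay. The step expected is a number no higher from compound 2 to compound 3 (the limit leaves the size open), roughly none beyond the scatter. Compound 3 is expected near 90 uM, between 30 uM and 200 uM, and may again be reported only as a limit.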

Compound 3, concentration for 50% inhibition: > 90 uM
Compound 3: no number, only a limit; the forecaster's own chance of this, stated with the estimate: 55%; the middle value lies on the limit itself.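

In this assay compound 2 and compound 3 each give only a limit, so no step between them can be read: the limit of > 90 uM in this assay, at which 2 of the 3 values shown sit.

The compounds shown leave open the size and direction of any effect of amino in place of dimethylamino on a double-bonded ring carbon.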